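The compounds below may be only part of what the source reports. "The series", "measured", "known", "first", "only" and "open" are said of these compounds alone.

Values in a functional assay on DU-145 cells (Homo sapiens) for antiproliferative activity, read by propidium iodide staining, with a stated time of 96 h; on this read-out lower numbers stand for stronger inhibition and higher numbers for weaker inhibition:
compound 1 `CC(O)(CSc1ccc(C(F)(F)F)cc1)C(=O)Nc1cccc(S(F)(F)(F)(F)F)c1`: 27200 nM
compound 2 `CC(O)(CSc1cccc(C(F)(F)F)c1)C(=O)Nc1cccc(S(F)(F)(F)(F)F)c1`: 19100 nM
compound 3 `CC(O)(CSc1cccc(OC(F)(F)F)c1)C(=O)Nc1cccc(S(F)(F)(F)(F)F)c1`: 25000 nM

Compound 2, at 19100 nM, is not separated from the other two measured compounds: the steps are a 1.4-fold lower number from compound 1 to compound 2 (0.15 log units; within the scatter) and a 1.3-fold higher number from compound 2 to compound 3 (0.12 log units; within the scatter).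

Compound 4 `CC(O)(CSc1cc(C(F)(F)F)cc(C(F)(F)F)c1)C(=O)Nc1cccc(S(F)(F)(F)(F)F)c1` follows from compound 2 by one change, a second trifluoromethyl in place of hydrogen on an aromatic carbon.

Among the measured compounds shown here, no measured step adds a group in this way. The nearest evidence is the two steps above, a shift of the trifluoromethyl and its exchange for trifluoromethoxy, and neither moved the number beyond the scatter. No clear shift in this assay is therefore expected.

The expected step is a 1.1-fold lower number from compound 2 to compound 4 (0.03 log units; within the scatter). Compound 4 is estimated at 18000 nM, with a range of 8000 nM to 38000 nM.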

Compound 4, half-maximal inhibitory concentration: 9400 nM
The estimate for compound 4 lay 1.9-fold (0.28 log units) above the measured number; low and high end bracket the measured number.
By their numbers in this assay, from the lowest: compound 4; then compounds 2, 3 and 1 (each within the scatter of the next).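

In this assay, the ring bearing the sulfur now gives a step beyond the scatter: a 2.0-fold lower number from compound 2 to compound 4 (0.31 log units; beyond the scatter), though a modest one. Among the compounds shown here, the two earlier changes on this ring, a shift of the trifluoromethyl and its exchange for trifluoromethoxy, stayed within the scatter, so adding a second trifluoromethyl on an aromatic carbon, meta to a trifluoromethyl group, is the only change here that separates two compounds. The data shown offer no measurement that accounts for this step.

As far as these compounds go, whether a fluorine, a methoxy or an amine on this aromatic carbon would give a similar step remains open. So does whether a second trifluoromethyl would have the same effect on compound 1 or compound 3.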